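The source may report more compounds than this note shows. Statements on the series, on what has been measured and on what is new or still open speak of the compounds shown alone.

Within the data shown here, in a physicochemical assay for lipophilicity, at pH 7.4 (a higher number here means a more lipophilic compound, a lower number a more polar compound), the values so far are as follows.

- Compound 1 `O=C(NC1CC1)C1CCN(c2cnccc2-c2ccccn2)CC1` gives 1.3
- Compound 2 `O=C(Nc1ccccc1)C1CCN(c2cncnc2-c2ccccc2)CC1` gives 2.7
- Compound 3 `CN(C)C(=O)C1CCN(c2cnccc2-c2ccccn2)CC1` gives 1.2

Compound 3 (1.2) lies within the scatter of compound 1 and well under compound 2 (2.7). Compound 4 `Cc1ccn(-c2ccncc2N2CCC(C(=O)N(C)C)CC2)n1` carries 3-methyl-1H-pyrazol-1-yl in place of pyridin-2-yl on an aromatic carbon. Among the measured compounds shown here, the one measured step (a number 0.10 log units lower from compound 1 to compound 3 (within the scatter)) puts dimethylamino in place of cyclopropylamino on a carbonyl carbon. For the measured compounds named here, it leaves the exchanged group untouched, so no measured step speaks directly to this change. With so little to go on, only a small upward step in this assay is expected, probably within the scatter (a number 0.20 log units higher from compound 3 to compound 4 (within the scatter)). The estimate for compound 4 is 1.4 and its expected range runs from 1 to 1.9 in this measurement.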

Compound 4, distribution coefficient: 1.5
The estimate for compound 4 lay 0.10 log units below the measured number; the measured number falls inside the stated range.
By their numbers in this assay, from the lowest: compounds 3, 1 and 4 (each within the scatter of the next); then compound 2.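

In this assay, among these compounds, the exchange on the aromatic carbon opposite the ring nitrogen gives a number 0.30 log units higher from compound 3 to compound 4 (within the scatter) for the first measured change at this position. A five-membered aromatic ring with 2 hetero atoms can thus replace a six-membered aromatic ring with 1 hetero atom here without a step beyond the scatter. Nothing measured explains this result.

Open, from the compounds shown here alone, is whether a carboxylic acid or a primary amine at this position would give a step beyond the scatter. Also open, going by these compounds, is whether the same exchange gives a similar step with the cyclopropylamino group of compound 1 on the carbonyl carbon.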